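The compounds below may be only part of what the source reports. "The series", "measured", "known", "first", "only" and "open" are said of these compounds alone.

Compound 1 `Cc1ccc(CNC(=O)C(C)c2ccc(NS(C)(=O)=O)c(F)c2)c(N2CCC(C)CC2)n1` gives 72.1 nM in an assay on CHO cells for antagonist activity at transient receptor potential cation channel subfamily V member 1 (Homo sapiens), read by FLIPR; a higher number here means a weaker inhibitor, a lower number a stronger inhibitor. Compound 2 `CC(C(=O)NCc1ccc(C2CC2)nc1N1CCCCC1)c1ccc(NS(C)(=O)=O)c(F)c1` gives 1.1 nM in this assay, and compound 3 `CC1CC(C)CN(c2nc(C(F)(F)Cl)ccc2CNC(=O)C(C)c2ccc(NS(C)(=O)=O)c(F)c2)C1` gives 1 nM in this assay. Compound 3 thus stands at the lowest number of the three: its value and that of compound 2 lie within the scatter of each other, while compound 1 sits far higher, beyond the scatter. Compound 4 `CC(C)COc1nc(C(F)(F)Cl)ccc1CNC(=O)C(C)c1ccc(NS(C)(=O)=O)c(F)c1` differs from compound 3 by isobutoxy in place of 3,5-dimethylpiperidin-1-yl on an aromatic carbon. Among the compounds with values here, no measured pair shows this change, so its size is open; the expected step of a 5.0-fold higher number from compound 3 to compound 4 (0.70 log units; beyond the scatter) is upward and modest, somewhat beyond the scatter. For compound 4 the expected value in this assay is 5 nM, within a range from 1 nM to 30 nM.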

Compound 4, inhibition constant: 0.6 nM
The estimate for compound 4 lay 8.3-fold (0.92 log units) above the measured number, outside the stated range (below it).
By their numbers in this assay, from the lowest: compounds 4, 3 and 2 (each within the scatter of the next); then compound 1.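

Replacing 3,5-dimethylpiperidin-1-yl with isobutoxy next to the ring nitrogen gives a 1.7-fold lower number from compound 3 to compound 4 (0.22 log units; within the scatter) in this assay and so leaves the two compounds indistinguishable. At this position, then, the six-membered non-aromatic ring is not required for a low number, and an oxygen can stand on the aromatic carbon in place of the ring nitrogen of the piperidine. Nothing at hand accounts for this result. The compounds shown leave open whether a shorter group such as methoxy or an open-chain amine such as diethylamino would keep the number this low. They also leave open whether isobutoxy would do so with a cyclopropyl group in place of chloro(difluoro)methyl.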